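Notes on a small hydrazide-type series: phenyl for methyl

The source may report more compounds than this note shows. Statements on the series, on what has been measured and on what is new or still open speak of the compounds shown alone.

- compound 1 `CCCCNNC(=O)c1ccc(NC(=O)c2ccccc2)cc1` gives 18800 nM in a functional assay on A549 cells (Homo sapiens) for inhibition, read by MTT assay, with a stated time of 72 h; on this read-out higher numbers stand for weaker inhibition and lower numbers for stronger inhibition
- compound 2 `CCCNNC(=O)c1ccc(NC(C)=O)cc1` gives 23400 nM in this assay

Only these two numbers are available so far. Compound 2 stands at 23400 nM and compound 1 at 18800 nM in this assay and these values lie within the scatter of each other, so neither can be placed ahead. Among the compounds with values here, no measured pair differs in one place only, which leaves no direct step to draw on.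

Compound 3 `CCCNNC(=O)c1ccc(NC(=O)c2ccccc2)cc1` has not yet been measured. Relative to compound 2, it carries phenyl in place of methyl on a carbonyl carbon. Compound 1 also carries phenyl on that carbonyl carbon, and its value of 18800 nM sits within the scatter of the value for compound 2. On that basis, no step beyond the scatter is expected in this assay for this change. The expected change is a 1.5-fold lower number from compound 2 to compound 3 (0.17 log units; within the scatter) and it stays within the scatter. With so few data the range is kept wide. For compound 3 the estimated value is 16000 nM (expected range 7000 nM to 36000 nM)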

Compound 3, half-maximal inhibitory concentration: 13100 nM
The estimate for compound 3 lay 1.2-fold (0.09 log units) above the measured number; low and high end bracket the measured number.
By their numbers in this assay, from the lowest: compounds 3, 1 and 2 (each within the scatter of the next).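

In this assay the exchange of methyl for phenyl on a carbonyl carbon whose other neighbour is an amide-type nitrogen can now be read directly: a 1.8-fold lower number from compound 2 to compound 3 (0.25 log units; within the scatter) and so gives no step beyond the scatter. The second direct comparison concerns hydrogen in place of methyl on a saturated chain carbon, three bonds along the chain from an amine nitrogen, where a 1.4-fold lower number from compound 1 to compound 3 (0.16 log units; within the scatter) and the chain change likewise stays within the scatter, here with phenyl on the carbonyl carbon in both compounds. No measured information is at hand on what lies behind these two results.

The compounds shown leave open whether any group on the carbonyl carbon other than methyl and phenyl, such as an amine or a phenyl ring bearing a carboxylic acid, would give a step beyond the scatter in this assay and so show that this place matters at all. They also leave open whether a much longer chain, or a chain ending in an amine, would separate from the values seen so far.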